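The compounds below may be only part of what the source reports. "The series", "measured", "known", "first", "only" and "open" are said of these compounds alone.

In a functional assay on K562 cells (Homo sapiens) for inhibition, read by MTT assay, with a stated time of 72 h (a higher number here means a weaker inhibitor, a lower number a stronger inhibitor), three compounds sharing one core have been measured. Compound 1 `O=[N+]([O-])c1ccc(-c2csc(N/N=C/c3ccc(C(F)(F)F)cc3)n2)cc1` gives 16900 nM, while compound 2 `FC(F)(F)c1ccc(/C=N/Nc2nc(-c3ccc(Cl)cc3Cl)cs2)cc1` gives 5480 nM, the lowest number of the three and so the strongest inhibition. Compound 3 `COc1ccc(-c2csc(N/N=C/c3ccc(C(F)(F)F)cc3)n2)cc1` reads > 66100 nM, which is a limit of the assay and not a number.

Compound 4 `FC(F)(F)c1ccc(/C=N/Nc2nc(-c3ccc(Cl)c(Cl)c3)cs2)cc1` keeps the atoms of compound 2 but joins them differently: 3,4-dichlorophenyl in place of 2,4-dichlorophenyl on an aromatic carbon. The change sits on an aromatic carbon of the five-membered ring, where 3,4-dichlorophenyl replaces 2,4-dichlorophenyl.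

Two measured steps changed this same aromatic group. The step of a 3.1-fold lower number from compound 1 to compound 2 (0.49 log units; beyond the scatter) was modest, and the step of an at least 12-fold higher number from compound 2 to compound 3 (1.08 log units; beyond the scatter) was large. Going by the values given here, both swapped one kind of group for another, whereas compound 4 keeps both chlorines, and no measured pair shows the effect of rearranging them. Only a small change is therefore expected, probably none beyond the scatter and with no favoured direction. The estimated change is a 1.1-fold higher number from compound 2 to compound 4 (0.04 log units; within the scatter). For compound 4 the expected value is 6000 nM, with an estimated range of 2500 nM to 15000 nM.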

Compound 4, half-maximal inhibitory concentration: > 60000 nM
Compound 4: no number, only a limit; the forecaster's own chance of this, stated with the estimate: 5%; at least 10-fold (1.00 log units) between middle value and limit.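

Moving one chlorine, with the same atoms on the ring, is enough to matter at this position in this assay: the result is an at least 10-fold higher number from compound 2 to compound 4 (1.03 log units; beyond the scatter). The earlier steps shown here each swapped one kind of group for another, whereas this one shows that keeping both chlorines does not by itself keep the inhibition, as 2,4-dichlorophenyl and 3,4-dichlorophenyl are not interchangeable here. The 3,4-dichlorophenyl group also falls behind 4-nitrophenyl, with an at least 3.5-fold higher number from compound 1 to compound 4 (0.55 log units; beyond the scatter), and compound 4 has only a limit, not a number, so its step against compound 3, also a limit, cannot be read: the limit of > 60000 nM in this assay, at which 1 of the 4 values shown sits.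

Going by these compounds, it stays open whether a phenyl group with a single chlorine, or with a methyl group or an amine in place of one chlorine, would read closer to compound 2 or to compound 4. These values also do not say why the two chlorine arrangements differ.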